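The source may hold more compounds than are shown below. What is called first, only, known or untested is meant among the compounds shown, and "the series" means these compounds.

Working notes on the series. All numbers come from a functional assay on ACHN cells (Homo sapiens) for cytotoxicity, read by sulforhodamine B assay, with a stated time of 72 h; a lower number here means a stronger inhibitor of growth, a higher number a weaker inhibitor of growth. Compound 1 `CCCC(=O)N1c2ccccc2CCC1C(=O)Nc1cc(C(F)(F)F)cc(C(F)(F)F)c1` gives 13900 nM. Compound 2 `COc1ccc(NC(=O)C2CCc3ccccc3N2)cc1` gives 38000 nM, and compound 3 `O=C(Nc1ccccc1O)C1CCc2ccccc2N1` gives 3990 nM. Among these three numbers compound 1 stands second highest: the nearest is compound 2, whose number lies higher by a gap beyond the scatter, and the furthest is compound 3, whose number lies lower, again beyond the scatter. For the measured compounds named here, no pair of measured compounds differs in only one place, so no measured step is available. Going by the values given here, compounds 2 and 3 carry a free ring nitrogen on the shared core but different anilide groups; their values show only that such compounds span the whole range seen here, from the lowest number to the highest.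

Compound 4 `O=C(Nc1cc(C(F)(F)F)cc(C(F)(F)F)c1)C1CCc2ccccc2N1` is not yet measured. It differs from compound 1 in one place: hydrogen in place of propylcarbonyl on a nitrogen on an aromatic ring in a ring. The propylcarbonyl leaves and a hydrogen atom enters on the ring nitrogen of the shared core.

Among the compounds with values here, no measured pair frames this change. The expected step of a 1.3-fold lower number from compound 1 to compound 4 (0.10 log units; within the scatter) is small, within the scatter or only modestly beyond it, with no firm direction. Compound 4 is expected to give 11000 nM, with a range from 3500 nM to 35000 nM.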

Compound 4, concentration for 50% growth inhibition: 8190 nM
For compound 4 the middle estimate is 1.3-fold (0.13 log units) above the measured one; the measured number falls inside the stated range.
By their numbers in this assay, from the lowest: compound 3; then compounds 4 and 1 (each within the scatter of the next); then compound 2.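

With the anilide group held fixed, replacing propylcarbonyl with hydrogen on the ring nitrogen of the shared core gives the first step readable at this position in this assay: a 1.7-fold lower number from compound 1 to compound 4 (0.23 log units; within the scatter). This assay therefore does not separate the acylated nitrogen from the free one in this anilide pair, and the 5 heavy atoms of the propylcarbonyl can leave without a step beyond the scatter. Nothing available on this pair bears on the reason for this result.

Going by these compounds, it remains open whether the same exchange would give a similarly small step with the anilide groups of compound 2 and compound 3, whose values lie far apart. On these data alone, it also remains open whether another group on this nitrogen, such as methyl, a longer acyl chain, benzoyl or an acyl chain ending in an amine or a carboxylic acid, would give a step beyond the scatter in either direction.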